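From Methylamino to Ethylamino

The source may report more compounds than this note shows. Statements on the series, on what has been measured and on what is new or still open speak of the compounds shown alone.

In a functional assay on A549 cells (Homo sapiens) for antiproliferative activity, read by MTT assay, with a stated time of 48 h (a lower number here means a stronger inhibitor, a higher number a weaker inhibitor), compound 1 `COc1ccc(C(=O)c2ccc3c(c2)C=CC(C)(C)O3)c(NC(=O)CBr)c1` gives 1980 nM and compound 2 `CNCC(=O)Nc1cc(OC)ccc1C(=O)c1ccc2c(c1)C=CC(C)(C)O2` gives 800 nM as the lower of the two numbers. Compound 3 `CCNCC(=O)Nc1cc(OC)ccc1C(=O)c1ccc2c(c1)C=CC(C)(C)O2` has methyl in place of hydrogen on a saturated chain carbon bound to an amine nitrogen, with methyl in place of hydrogen on a saturated chain carbon bound to an amine nitrogen as the counted difference. For the measured compounds named here, the only measured step, a 2.5-fold lower number from compound 1 to compound 2 (0.39 log units; beyond the scatter) with methylamino in place of bromo, is modest and does not test this change, so in this assay no step beyond the scatter is expected. The estimated step is an expected 1.1-fold lower number from compound 2 to compound 3 (0.03 log units; within the scatter). Compound 3 is estimated at 750 nM with an expected range from 350 nM to 1700 nM for repeated measurements.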

Compound 3, half-maximal inhibitory concentration: 1300 nM
Compound 3: middle estimate off by 1.7-fold (0.24 log units), on the low side; the range from low to high includes it.
By their numbers in this assay, from the lowest: compounds 2, 3 and 1 (each within the scatter of the next, the first and the last beyond it).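

In this assay, methyl in place of hydrogen on the saturated chain carbon bound to an amine nitrogen gives a 1.6-fold higher number from compound 2 to compound 3 (0.21 log units; within the scatter), so going from methylamino to ethylamino leaves no readable difference at this position. Ethylamino in place of bromo gives a 1.5-fold lower number from compound 1 to compound 3 (0.18 log units; within the scatter), so ethylamino does not stand clear of bromo as methylamino did. Nothing measured here speaks to a cause for these steps. Still open, as far as these compounds go, is how a propylamino chain, a dimethylamino group or a piperidine ring would read on this carbon, and whether any would stand clear of methylamino.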